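This account rests on a few compounds, and the source may have more. Where it says the series, first, only, none or still open, it means among the compounds named here.

Compound 1, `CC(c1ccc2ncc(-c3cnn(C)c3)cc2c1)n1nnc2ncc(-c3ccc(C(N)=O)c(F)c3)nc21`: in an ADME assay on microsomes from liver (Rattus norvegicus) for metabolic stability, read by LC-MS, using NADPH, with stated times of 5 min and 30 min, tested at 1 uM (a higher number here means faster removal of the compound, a lower number slower removal), compound 1 gives 10 uL/min.
Compound 2, `CC(c1ccc2ncc(-c3cnn(C)c3)cc2c1)n1nnc2ncc(-c3ccncc3)nc21`: in this assay compound 2 gives 61 uL/min.
Compound 3, `CC(c1cc2cc(-c3cnn(C)c3)cnc2cc1F)n1nnc2ncc(-c3ccc(C(N)=O)c(F)c3)nc21`: in this assay compound 3 gives 1 uL/min.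

Compound 3 stands lowest of the three in this assay: compound 1 lies above it by a 10-fold lower number from compound 1 to compound 3 (1.00 log units; beyond the scatter) reversed, and compound 2 stands higher still. The two measured steps are a 6.1-fold higher number from compound 1 to compound 2 (0.79 log units; beyond the scatter) and a 10-fold lower number from compound 1 to compound 3 (1.00 log units; beyond the scatter); both are of modest size and beyond the scatter, but neither touches the amide.

Compound 4, `CNC(=O)c1ccc(-c2cnc3nnn(C(C)c4cc5cc(-c6cnn(C)c6)cnc5cc4F)c3n2)cc1F`, has not been measured in this assay. It differs from compound 3 by methyl in place of hydrogen on an amide-type nitrogen. For the measured compounds named here, no measured pair shows this change, so nothing among the three compounds bears on it directly; the only guidance is that the shared core with the 4-carbamoyl-3-fluorophenyl group and the fluoro on the other ring gave the lowest value in the set. A step no larger than the scatter, or at most slightly upward, is therefore expected for compound 4, that is a 2.0-fold higher number from compound 3 to compound 4 (0.30 log units; within the scatter). Compound 4 is estimated at 2 uL/min, with a range from 0.7 uL/min to 6 uL/min.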

Compound 4, intrinsic clearance in a liver preparation (reported as CLH), per the amount of preparation that the assay uses: 12 uL/min
Compound 4: the middle estimate sits 6.0-fold (0.78 log units) below what was measured; measured number outside the range, above it.
By their numbers in this assay, from the lowest: compound 3; then compounds 1 and 4 (each within the scatter of the next); then compound 2.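

The amide nitrogen of the 4-carbamoyl-3-fluorophenyl group turns out to be a sensitive position: in this assay, methyl in place of the amide hydrogen gives a 12-fold higher number from compound 3 to compound 4 (1.08 log units; beyond the scatter) and adds only one carbon. For the compounds shown here, the earlier steps replaced the whole aromatic group or added fluoro on an aromatic carbon, so this is the first of the steps to show that a change on the amide itself moves the read-out. Nothing measured here accounts for the size of this step.

The compounds shown leave open whether an ethyl group or a longer chain on that nitrogen would push the number higher still, and whether a carboxylic acid would behave like either amide. They also leave open whether the same methyl would give a similar step on the core of compound 1, which lacks the fluoro.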